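A few compounds are considered here, and "the series" means these few. Any claim that something is new, unique, unknown or untested is made for them only; others in the source may bear on it.

Working notes on the series. Compound 1 `Cc1c(OCCCCOc2ccc(C(=O)O)cc2)ccc(C(=O)CC2CCCC2)c1O` and compound 2 `Cc1c(OCCCCOc2ccc(C(=O)O)cc2)ccc(C(=O)CC(C)C)c1O` share one core and differ only on the chain carbon bound to the carbonyl carbon. In an assay on HEK293 cells for positive allosteric modulation of metabotropic glutamate receptor 3 (Rattus norvegicus), read by thallium flux, with a stated time of 2.5 min (on this read-out lower numbers stand for smaller maximal responses and higher numbers for larger maximal responses), compound 1 gives 26.7%, while compound 2 gives 51.9%. Among the compounds with values here, the one measured step, a number 25.2 percentage points higher from compound 1 to compound 2 (beyond the scatter), follows isopropyl in place of cyclopentyl on a saturated chain carbon bound to a carbonyl carbon. Within the data shown here, compound 2 therefore stands highest of the two numbers, with compound 1 as its only neighbour, beyond the scatter below it.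

Compound 3 `Cc1c(OCCCCOc2ccc(F)c(C(=O)O)c2)ccc(C(=O)CC(C)C)c1O` departs from compound 2 at the other end of the molecule: 3-carboxy-4-fluorophenyl in place of 4-carboxyphenyl on an oxygen on a saturated carbon. Among the measured compounds shown here, no measured step touches this part of the structure; the only step available concerns the chain carbon and says nothing about the carboxyphenyl end. There is thus no basis for expecting a step beyond the scatter in this assay in either direction. The maximal response of compound 3 is expected close to that of compound 2, estimated at 50% with a range of 30% to 70%. The expected step is a number 1.9 percentage points lower from compound 2 to compound 3 (within the scatter).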

Compound 3, largest response reached (reported as percent of maximum), in percent of the reference or control that the assay uses: 81.7%
Beside the measured number, compound 3's estimate is 31.7 percentage points below it; measured number above the stated range.
By their numbers in this assay, from the lowest: compound 1; then compound 2; then compound 3.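

The carboxyphenyl end of the molecule also moves the read-out: in this assay, 3-carboxy-4-fluorophenyl in place of 4-carboxyphenyl gives a number 29.8 percentage points higher from compound 2 to compound 3 (beyond the scatter), so the chain carbon, with a number 25.2 percentage points higher from compound 1 to compound 2 (beyond the scatter), is not the only place in the series where the maximal response changes beyond the scatter. This single change both moves the carboxy group on the aromatic ring and adds a fluorine, and the step cannot divide its size between the two. The data shown offer no measured explanation for the rise.

Open, on these data alone, is what a 3-carboxyphenyl group on the same oxygen would give, which would separate the carboxy placement from the fluorine. Also open, as far as these compounds go, is whether the gain from 3-carboxy-4-fluorophenyl carries over when cyclopentyl replaces isopropyl on the chain carbon.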